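Urea aryl substitution in the diaryl ether series

The source may report more compounds than this note shows. Statements on the series, on what has been measured and on what is new or still open speak of the compounds shown alone.

Compound 3 `COc1cc2cc(Oc3ccc(NC(=O)Nc4ccc(Cl)c(C(F)(F)F)c4)cc3)c(C)nc2cc1OC` gives -25.7% in a functional assay on MDA-MB-435 cells (Homo sapiens) for inhibition, read by sulforhodamine B assay, with a stated time of 48 h, tested at 10 uM (a lower number here means a stronger effect, a higher number a weaker effect of the compound at the concentration tested), the lowest of the three numbers here and beyond the scatter from both others. Compound 1 `COc1cc2cc(Oc3ccc(NC(=O)Nc4ccccc4)cc3)c(C)nc2cc1OC` gives 89.4% and compound 2 `COc1cc2cc(Oc3ccc(NC(=O)Nc4ccc(C(F)(F)F)cc4)cc3)c(C)nc2cc1OC` gives 80.3% in this assay; the step of a number 9.1 percentage points lower from compound 1 to compound 2 (within the scatter) lies within the scatter, whereas a number 115.1 percentage points lower from compound 1 to compound 3 (beyond the scatter) and a number 106 percentage points lower from compound 2 to compound 3 (beyond the scatter) are both large and beyond it. Compound 4 `COc1cc2cc(Oc3ccc(NC(=O)Nc4ccc(Cl)c(Cl)c4)cc3)c(C)nc2cc1OC` is not yet measured. It differs from compound 3 by chloro in place of trifluoromethyl on an aromatic carbon. For the measured compounds named here, the steps that bear on it are those into compound 3, a number 115.1 percentage points lower from compound 1 to compound 3 (beyond the scatter) and a number 106 percentage points lower from compound 2 to compound 3 (beyond the scatter), where the exchange of the urea aryl group for 4-chloro-3-(trifluoromethyl)phenyl gave the whole drop; the step of a number 9.1 percentage points lower from compound 1 to compound 2 (within the scatter) shows that trifluoromethyl alone on that ring left the number where it was. Going by the values given here, no measured pair separates the chloro from the trifluoromethyl. Compound 4 is therefore expected to stay near compound 3, with a modest rise allowed for, so that the expected step is a number 30.7 percentage points higher from compound 3 to compound 4 (beyond the scatter). The estimate for compound 4 in this assay is 5%, with a range from -30% to 55%.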

Compound 4, a percentage reported as activity, at one concentration (the size of the read-out at that concentration, not a potency): 12.3%
Compound 4: the middle estimate sits 7.3 percentage points below what was measured, within the range that was stated.
By their numbers in this assay, from the lowest: compound 3; then compound 4; then compounds 2 and 1 (each within the scatter of the next).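

In this assay, for the compounds shown here, this is the first pair that separates chloro from trifluoromethyl on the aromatic carbon ortho to a chloro group, and the swap gives a number 38 percentage points higher from compound 3 to compound 4 (beyond the scatter), so this position is sensitive to which of the two groups it carries. The trifluoromethyl group is still not required for a large drop: 3,4-dichlorophenyl in place of 4-(trifluoromethyl)phenyl gives a number 68 percentage points lower from compound 2 to compound 4 (beyond the scatter), and 3,4-dichlorophenyl in place of phenyl gives a number 77.1 percentage points lower from compound 1 to compound 4 (beyond the scatter). No measurement at hand accounts for the difference between chloro and trifluoromethyl at this position.

As far as these compounds go, it remains open whether a single chloro group on this aryl ring, with no second group, would be enough for such a drop. Also open, from the compounds shown here alone, is what a non-halogen group, such as methyl, methoxy or an amine, would give on the same aromatic carbon.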